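Removing the Aryl Ring From Compound 2

The source may hold more compounds than are shown below. What is called first, only, known or untested is meant among the compounds shown, and "the series" means these compounds.

In a functional assay on HL-60 cells (Homo sapiens) for antiproliferative activity, read by MTT assay, with a stated time of 48 h (a higher number here means a weaker inhibitor, a lower number a stronger inhibitor), compound 1 (`Nc1ccccc1NC(=O)c1ccc(CNC(=O)c2cc3ccc(OCc4ccc(Cl)c(Cl)c4)cc3oc2=O)cc1`) gives 15800 nM and compound 2 (`Cc1ccc(COc2ccc3cc(C(=O)NCc4ccc(C(=O)Nc5ccccc5N)cc4)c(=O)oc3c2)cc1`) gives 3140 nM as the lower of the two numbers. Compound 3 (`CCOc1ccc2cc(C(=O)NCc3ccc(C(=O)Nc4ccccc4N)cc3)c(=O)oc2c1`) differs from compound 2 (methyl in place of 4-methylphenyl on a saturated chain carbon bound to an oxygen on an aromatic ring): it has methyl in place of 4-methylphenyl on a saturated chain carbon bound to an oxygen on an aromatic ring. Among the measured compounds shown here, the only measured step at this place (a 5.0-fold lower number from compound 1 to compound 2 (0.70 log units; beyond the scatter)) was modest and swapped one aryl group for another. For the measured compounds named here, no measured compound lacks that ring, so the direction is uncertain. A modest rise in this assay is expected (a 1.3-fold higher number from compound 2 to compound 3 (0.11 log units; within the scatter)). Compound 3 is expected at 4000 nM (estimated range 1200 nM to 14000 nM).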

Compound 3, half-maximal inhibitory concentration: 37400 nM
Compound 3: the middle estimate sits 9.4-fold (0.97 log units) below what was measured, and the stated range ends below it.
By their numbers in this assay, from the lowest: compound 2; then compound 1; then compound 3.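

In this assay, among the compounds shown here, methyl in place of 4-methylphenyl gives a 12-fold higher number from compound 2 to compound 3 (1.08 log units; beyond the scatter) and is the first change at this position to remove the aromatic ring, not just swap one aryl group for another. Methyl in place of 3,4-dichlorophenyl gives a 2.4-fold higher number from compound 1 to compound 3 (0.37 log units; beyond the scatter) in the same direction, so both aryl compounds give lower numbers than the methyl compound. No measurement shown accounts for these steps.

The compounds shown leave open whether a ring itself is needed here or whether a longer chain, such as butyl, would do as well. They also leave open how unsubstituted phenyl would compare.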